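Turning the Double Bond in Compound 1

This account rests on a few compounds, and the source may have more. Where it says the series, first, only, none or still open, it means among the compounds named here.

In a functional assay on HeLa cells (Homo sapiens) for antiproliferative activity, read by MTT assay, with a stated time of 72 h (a lower number here means a stronger inhibitor, a higher number a weaker inhibitor), compound 1 (`C=C(Br)C(=O)Nc1ccc2c(c1)/C(=C\c1ccc(C)s1)C(=O)N2`) gives 2000 nM, the higher of the two measured numbers, while compound 2 (`C=C(Br)C(=O)Nc1ccc2c(c1)/C(=C\c1sccc1C)C(=O)N2`) gives 450 nM. Compound 3 (`C=C(Br)C(=O)Nc1ccc2c(c1)/C(=C/c1ccc(C)s1)C(=O)N2`) has yet to be measured. Set against compound 1, (the two compounds have the same atoms and bonds and differ only in configuration as drawn: 1 of 1 stereo elements differ; a double bond is drawn E in compound 1 and Z in compound 3). Among the measured compounds shown here, the only measured step, a 4.4-fold lower number from compound 1 to compound 2 (0.65 log units; beyond the scatter), places 3-methylthiophen-2-yl in place of 5-methylthiophen-2-yl and lies beyond the scatter, but it leaves the configuration unchanged. For the measured compounds named here, no measured pair therefore shows what a change from E to Z does, and the direction remains uncertain. Going by the values given here, with compound 1 at 2000 nM, the top of the measured numbers, a modest move to a lower number, no larger than that step, is expected. The estimated step is a 1.7-fold lower number from compound 1 to compound 3 (0.22 log units; within the scatter). For compound 3 the expected value is 1200 nM, with an estimated range from 350 nM to 4000 nM.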

Compound 3, half-maximal inhibitory concentration: 1600 nM
Estimate against measurement, compound 3: 1.3-fold (0.12 log units) below, within the range that was stated.
By their numbers in this assay, from the lowest: compound 2; then compounds 3 and 1 (each within the scatter of the next).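

In this assay, turning the double bond from E to Z comes to a 1.3-fold lower number from compound 1 to compound 3 (0.10 log units; within the scatter), so with 5-methylthiophen-2-yl in place the two configurations cannot be told apart. Among the compounds shown here, the earlier step, a 4.4-fold lower number from compound 1 to compound 2 (0.65 log units; beyond the scatter), changed the group and left the configuration as it was, so the configuration is tested on its own for the first time here. This pair can be read as a test of the double bond alone on one ground: the fact that compounds 1 and 3 differ only in the configuration as drawn

The compounds shown leave open whether the configuration counts for as little with the 3-methylthiophen-2-yl group of compound 2. They also leave open what an amine or a carboxylic acid in place of the methyl would do in either configuration.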